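Adding a Methoxy Group to the Anilino Ring

This account rests on a few compounds, and the source may have more. Where it says the series, first, only, none or still open, it means among the compounds named here.

Compound 1 `Cc1nc(SCC(=O)Nc2nc(-c3ccc(Cl)cc3)cs2)n(Nc2ccccc2)c1C` was tested in a functional assay on SK-OV-3 cells (Homo sapiens) for antiproliferative activity, read by sulforhodamine B assay, with a stated time of 48 h (on this read-out lower numbers stand for stronger inhibition of growth and higher numbers for weaker inhibition of growth), where compound 1 gives 5910 nM. Among the measured compounds shown here, compound 2 `Cc1ccc(Nn2c(SCC(=O)Nc3nc(-c4ccccc4)cs3)nc(C)c2C)cc1`, the only other measured compound, gives in this assay 10600 nM. These two numbers lie within the scatter of each other, so compound 1 simply holds the lower of the two without standing apart. Compound 3 `COc1ccc(Nn2c(SCC(=O)Nc3nc(-c4ccc(Cl)cc4)cs3)nc(C)c2C)cc1` differs from compound 1 by methoxy in place of hydrogen on an aromatic carbon. For the measured compounds named here, no measured pair shows this change, so the step is expected to stay within the scatter, with no clear direction. The estimate for compound 3 in this assay is 7000 nM, ranging from 3000 nM to 17000 nM. This corresponds to an expected step of a 1.2-fold higher number from compound 1 to compound 3 (0.07 log units; within the scatter).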

Compound 3, concentration for 50% growth inhibition: 4240 nM
Beside the measured number, compound 3's estimate is 1.7-fold (0.22 log units) above it; measured number inside the range.
By their numbers in this assay, from the lowest: compounds 3, 1 and 2 (each within the scatter of the next, the first and the last beyond it).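

In this assay, placing methoxy on the anilino ring, para to a large group, gives a 1.4-fold lower number from compound 1 to compound 3 (0.14 log units; within the scatter) and so shows that this position takes a group larger than hydrogen without a clear shift in growth inhibition. Nothing available offers an explanation for this result.

Among the compounds shown here, with only this one change at this position, it stays open whether a different group here, such as an amine or a carboxylic acid, would move the number beyond the scatter.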